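Vinyl to 1-methyl-1H-pyrazol-4-yl on the aromatic carbon

This account rests on a few compounds, and the source may have more. Where it says the series, first, only, none or still open, it means among the compounds named here.

In a functional assay on HCT-116 cells (Homo sapiens) for inhibition, read by CCK-8 assay, with a stated time of 48 h (a higher number here means a weaker inhibitor, a lower number a stronger inhibitor), compound 1 `COc1cc(-c2ccnc3cc(-c4ccc(F)cc4)nn23)cc(OC)c1OC` gives 5030 nM, compound 2 `COc1cc(-c2ccnc3cc(-c4ccc(C(F)(F)F)cc4)nn23)cc(OC)c1OC` gives 1860 nM and compound 3 `C=Cc1ccc(-c2cc3nccc(-c4cc(OC)c(OC)c(OC)c4)n3n2)cc1` gives 1060 nM. Compound 3 lies within the scatter of compound 2 and beyond it from compound 1. Compound 4 `COc1cc(-c2ccnc3cc(-c4ccc(-c5cnn(C)c5)cc4)nn23)cc(OC)c1OC` carries 1-methyl-1H-pyrazol-4-yl in place of vinyl on an aromatic carbon. Among the measured compounds shown here, three measured steps bear on this change: a 2.7-fold lower number from compound 1 to compound 2 (0.43 log units; beyond the scatter) and a 4.7-fold lower number from compound 1 to compound 3 (0.68 log units; beyond the scatter) are modest, while a 1.8-fold lower number from compound 2 to compound 3 (0.24 log units; within the scatter) stays within the scatter. None of them brings in a ring, so they guide only loosely. The expected change in this assay is a 1.1-fold lower number from compound 3 to compound 4 (0.03 log units; within the scatter), nothing beyond the scatter. For compound 4 the estimate is 1000 nM, with an expected range of 250 nM to 4000 nM.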

Compound 4, half-maximal inhibitory concentration: 2110 nM
Compound 4: the middle estimate sits 2.1-fold (0.32 log units) below what was measured, and the stated range covers the measured number.
By their numbers in this assay, from the lowest: compounds 3, 2 and 4 (each within the scatter of the next); then compound 1.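

Adding a ring at this position, para to a large group, costs little: a 2.0-fold higher number from compound 3 to compound 4 (0.30 log units; within the scatter) and a 1.1-fold higher number from compound 2 to compound 4 (0.05 log units; within the scatter) leave 1-methyl-1H-pyrazol-4-yl unseparated from vinyl and trifluoromethyl, despite its larger size and two hydrogen-bond acceptors. Compound 4 also keeps an advantage over the fluoro compound, with a 2.4-fold lower number from compound 1 to compound 4 (0.38 log units; beyond the scatter) as the step that lies beyond the scatter. No measurement here speaks to the cause of these steps.

As far as these compounds go, whether an amine or a carboxylic acid at this place would move the number beyond the scatter stays open. Also open, from the compounds shown here alone, is how an unmethylated pyrazole or a phenyl ring would compare with compound 4.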